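Nitro in place of hydrogen: from compound 3 to compound 4

This account rests on a few compounds, and the source may have more. Where it says the series, first, only, none or still open, it means among the compounds named here.

Measured so far in an ADME assay on RAW264.7 cells (Mus musculus) for cytotoxicity, read by MTT assay, with a stated time of 72 h, tested at 50 uM; on this read-out higher numbers stand for a stronger effect at the one concentration tested and lower numbers for a weaker effect:
Compound 1, `O=C(Cn1c(=O)oc2cc([N+](=O)[O-])ccc21)Nc1ccccn1`: 38.6%
Compound 2, `O=C(Cn1c(=O)oc2cc(Cl)ccc21)NCc1cccs1`: 20.3%
Compound 3, `O=C(Cn1c(=O)oc2ccccc21)NCc1cccs1`: 23.4%

Compound 3 stands second highest of the three numbers in this assay. Its nearest neighbour is compound 2, and the step of a number 3.1 percentage points higher from compound 2 to compound 3 (within the scatter) lies within the scatter; the furthest is compound 1, whose number lies higher than that of compound 3 by more than the scatter. Compound 4, `O=C(Cn1c(=O)oc2cc([N+](=O)[O-])ccc21)NCc1cccs1`, differs from compound 3 in one place: nitro in place of hydrogen on an aromatic carbon. Among the compounds with values here, only one measured step touches the same position, a number 3.1 percentage points higher from compound 2 to compound 3 (within the scatter), and it was small. Within the data shown here, compound 1 also carries a nitro group at that place, but its amide part differs as well, so no single-change step links it to compound 3 or compound 4; its value shows only that the one nitro-bearing compound gave the highest number here. On that basis a moderate upward step in this assay is expected, a number 8.6 percentage points higher from compound 3 to compound 4 (within the scatter). Compound 4 is therefore estimated at 32%, in the range 18% to 46%.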

Compound 4, a percentage reported as inhibition, at one concentration (the size of the read-out at that concentration, not a potency): 36.6%
Estimate against measurement, compound 4: 4.6 percentage points below; low and high end bracket the measured number.
By their numbers in this assay, from the lowest: compounds 2 and 3 (each within the scatter of the next); then compounds 4 and 1 (each within the scatter of the next).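

In this assay this place on the aromatic carbon turns out to be able to move the read-out: the earlier swap of chloro for hydrogen was small, whereas nitro in place of hydrogen gives a number 13.2 percentage points higher from compound 3 to compound 4 (beyond the scatter) and nitro in place of chloro gives a number 16.3 percentage points higher from compound 2 to compound 4 (beyond the scatter) on the same core. With nitro kept, (thiophen-2-yl)methyl in place of pyridin-2-yl on an amide-type nitrogen gives a number 2 percentage points lower from compound 1 to compound 4 (within the scatter) and so leaves no readable mark in this pair. Nothing measured here offers a reason for the rise with nitro.

The compounds shown leave open whether an amine or a carboxylic acid at this place would give a similar number to nitro. They also leave open whether nitro would have the same result at another carbon of the ring, or with a longer chain on the amide nitrogen.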